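Replacing the pyridinyl amide of compound 1 with a piperidinylmethyl amide

The compounds below may be only part of what the source reports. "The series", "measured", "known", "first", "only" and "open" are said of these compounds alone.

Measured so far:
compound 1, `O=C(c1ccccn1)N1CCC(NS(=O)(=O)c2cc(S(=O)(=O)c3ccccc3)ccc2C(F)(F)F)CC1`, 100000 nM
compound 2, `O=C(O)CCCC(=O)N1CCC(NS(=O)(=O)c2cc(S(=O)(=O)c3ccccc3)ccc2C(F)(F)F)CC1`, 50000 nM

Compound 1 holds the highest of the two numbers in a physicochemical assay for solubility (a higher number here means a more soluble compound, a lower number a less soluble compound), though its nearest neighbour, compound 2, sits close by: a 2.0-fold lower number from compound 1 to compound 2 (0.30 log units; within the scatter). Compound 3, `O=C(CC1CCNCC1)N1CCC(NS(=O)(=O)c2cc(S(=O)(=O)c3ccccc3)ccc2C(F)(F)F)CC1`, has not yet been measured in this assay. It differs from compound 1 at one place: (piperidin-4-yl)methyl in place of pyridin-2-yl on a carbonyl carbon. Going by the values given here, the only measured step that touches the same carbonyl carbon is the one from compound 1 to compound 2, and it stayed within the scatter. With nothing in the data pointing to a larger shift, the step to compound 3 is expected to be small, and the estimate for compound 3 is a 1.5-fold higher number from compound 1 to compound 3 (0.18 log units; within the scatter), in effect no change beyond the scatter. Compound 3 is therefore estimated at 150000 nM, with a likely range from 50000 nM to 400000 nM.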

Compound 3, solubility: 100000 nM
Beside the measured number, compound 3's estimate is 1.5-fold (0.18 log units) above it; low and high end bracket the measured number.
By their numbers in this assay, from the lowest: compounds 2, 1 and 3 (each within the scatter of the next).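

With (piperidin-4-yl)methyl on the carbonyl carbon, this assay records no change at the digits printed from compound 1 to compound 3 (within the scatter) and also a 2.0-fold higher number from compound 2 to compound 3 (0.30 log units; within the scatter) for the same compound. A six-membered non-aromatic ring carrying a hydrogen-bond donor therefore stands at this place with a number that cannot be separated, within the scatter, from those of the aromatic pyridin-2-yl and the 3-carboxypropyl chain. Going by these compounds alone, three quite different groups on this one carbonyl carbon now read alike, which the single earlier step could only hint at. From the compounds shown here alone, whether a plain alkyl chain, a morpholine ring or a primary amine on a longer chain would give a number outside the scatter remains open. Nothing measured here explains why these three groups read alike.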